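Lipophilicity of an oxime-ring series: adding a phenolic hydroxyl

A few compounds are considered here, and "the series" means these few. Any claim that something is new, unique, unknown or untested is made for them only; others in the source may bear on it.

Measured compounds in a physicochemical assay for lipophilicity; on this read-out lower numbers stand for lower lipophilicity and higher numbers for higher lipophilicity:
- compound 1 `C[C@H]1CC[C@@H]2[C@@H](OC(=O)[C@]23CC(c2c(Cl)cccc2Cl)=NO3)[C@]2(C)C(=O)C=C[C@@]12O`: 2.67
- compound 2 `COc1ccc(C2=NO[C@]3(C2)C(=O)O[C@@H]2[C@H]3CC[C@H](C)[C@]3(O)C=CC(=O)[C@@]23C)cc1`: 1.47
- compound 3 `C[C@H]1CC[C@@H]2[C@@H](OC(=O)[C@]23CC(c2ccc(N(C)C)cc2)=NO3)[C@]2(C)C(=O)C=C[C@@]12O`: 1.51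

Compound 2 has the lowest of the three numbers in this assay. Its nearest neighbour is compound 3, which lies a number 0.04 log units higher from compound 2 to compound 3 (within the scatter), a gap within the scatter, so the two cannot be ordered. Compound 1 lies furthest away: the swap of its 2,6-dichlorophenyl for 4-methoxyphenyl gives a number 1.20 log units lower from compound 1 to compound 2 (beyond the scatter), and the swap for 4-(dimethylamino)phenyl gives a number 1.16 log units lower from compound 1 to compound 3 (beyond the scatter).

Compound 4 `COc1cc(C2=NO[C@]3(C2)C(=O)O[C@@H]2[C@H]3CC[C@H](C)[C@]3(O)C=CC(=O)[C@@]23C)ccc1O` is not yet measured. It differs from compound 2 in one place: 4-hydroxy-3-methoxyphenyl in place of 4-methoxyphenyl on a carbon with a double bond to nitrogen.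

Of the measured steps, a number 0.04 log units higher from compound 2 to compound 3 (within the scatter) is the closest comparison, since it also exchanges one group on the aromatic ring of the 4-methoxyphenyl, and it stayed within the scatter. The two large steps from compound 1 involved exchanging the whole aryl group, not adding a hydroxyl, so they do not transfer directly. Going by the values given here, no measured step shows the effect of a hydroxyl here.

The hydroxyl of compound 4 is expected to lower the number by a modest amount, giving a number 0.42 log units lower from compound 2 to compound 4 (beyond the scatter). Compound 4 is therefore estimated at 1.05, in the range 0.65 to 1.45.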

Compound 4, partition coefficient: 0.75
Compound 4: the middle estimate sits 0.30 log units above what was measured; low and high end bracket the measured number.
By their numbers in this assay, from the lowest: compound 4; then compounds 2 and 3 (each within the scatter of the next); then compound 1.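

In this assay, the aryl group on the carbon with a double bond to nitrogen can take the series lower than any earlier compound did, with a number 0.72 log units lower from compound 2 to compound 4 (beyond the scatter) as 4-hydroxy-3-methoxyphenyl, which carries a hydrogen-bond donor, replaces 4-methoxyphenyl, which carries none. The earlier exchange of one group on this ring left compound 2 and compound 3 within the scatter of each other, whereas the new aryl group stands clearly apart from both, with a number 0.76 log units lower from compound 3 to compound 4 (beyond the scatter) as the matching comparison. The whole span across these aryl groups also widens, since a number 1.92 log units lower from compound 1 to compound 4 (beyond the scatter) exceeds either step seen from compound 1 before, and compound 4 is now the lowest of the four.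

No information here accounts for the drop. The hydroxyl and the extra methoxy arrive together in one aryl group, so their shares of the step stay unknown, and the compounds shown do not tell whether a simple 4-hydroxyphenyl, or a carboxylic acid or a primary amine on the same ring, would move the number further.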